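This account rests on a few compounds, and the source may have more. Where it says the series, first, only, none or still open, it means among the compounds named here.

Measured so far:
- compound 1 `COc1cc(C(=O)/C(=C\c2ccc([N+](=O)[O-])c(O)c2)SCc2ccc(Br)cc2)cc(OC)c1OC` — 1000 nM
- compound 2 `O=C(/C(=C\c1ccc(O)cc1O)Sc1ccccc1Br)c1ccc(Br)cc1` — 50000 nM
- compound 3 `CN(C)c1ccc(/C=C(/SCc2ccc(F)cc2)C(=O)c2ccc(C(=O)O)cc2)cc1` — 10000 nM

All three were run in a functional assay on DU-145 cells (Homo sapiens) for inhibition, read by trypan blue exclusion, with a stated time of 96 h; a lower number here means a stronger inhibitor of growth, a higher number a weaker inhibitor of growth. On the numbers shown, compound 1 gives the lowest value of the three in this assay. Compound 3 is the nearest to it, and the gap between them is beyond the scatter; compound 2 is the furthest from it, and that gap too is beyond the scatter. No pair of these compounds differs in a single place, so no step between measured compounds is available to lean on.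

The next compound, compound 4 `COc1cc(C(=O)/C(=C\c2ccc(O)c([N+](=O)[O-])c2)SCc2ccc(Br)cc2)cc(OC)c1OC`, keeps the core of compound 1 and the same atoms, joined differently: 4-hydroxy-3-nitrophenyl in place of 3-hydroxy-4-nitrophenyl on a double-bonded chain carbon bound to a double-bonded chain carbon. The hydroxyl and nitro groups simply trade positions on the same ring that hangs from the double-bonded chain carbon.

With no measured step of this kind in the set, the expectation for this assay is a step from compound 1 to compound 4 of modest size, if any, most likely within the scatter, with a slight lean toward a higher number. The estimated step is a 1.5-fold higher number from compound 1 to compound 4 (0.18 log units; within the scatter). For compound 4 the expected value is 1500 nM, with a range from 500 nM to 5000 nM.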

Compound 4, concentration for 50% growth inhibition: 1000 nM
For compound 4 the middle estimate is 1.5-fold (0.18 log units) above the measured one; measured number inside the range.
By their numbers in this assay, from the lowest: compounds 1 and 4 (each within the scatter of the next); then compound 3; then compound 2.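

In this assay, for the compounds shown here, 4-hydroxy-3-nitrophenyl in place of 3-hydroxy-4-nitrophenyl on a double-bonded chain carbon bound to a double-bonded chain carbon gives no change at the digits printed from compound 1 to compound 4 (within the scatter) and is the only step in the set that changes one place. On the core of compound 1, the two arrangements of the hydroxyl and nitro groups on this ring therefore cannot be told apart in this read-out, so trading their positions does not by itself shift the number. No measurement at hand explains this lack of separation.

From the compounds shown here alone, what happens when either group is replaced outright stays open, for instance an amine in place of the nitro group or a methoxy group in place of the hydroxyl, and so does whether this ring needs both groups at all. One step on one core also cannot show whether the same swap would be as silent with other parts of the molecule changed, such as a carboxylic acid on the ring of the aryl ketone or a longer chain on the sulfur.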